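Swapping the Aryl Group on the Ring That Bears It

The source may report more compounds than this note shows. Statements on the series, on what has been measured and on what is new or still open speak of the compounds shown alone.

Compound 1 `CCOC(=O)C1=Cc2ccccc2OC1(OCc1cc(-c2ccc(C)cc2)no1)C(F)(F)F`: in a functional assay on A549 cells (Homo sapiens) for inhibition, read by MTT assay, with a stated time of 24 h (a lower number here means a stronger inhibitor, a higher number a weaker inhibitor), compound 1 gives only a limit, > 150000 nM.
Compound 2 `Cc1ccc(-c2cc(COC3(C(F)(F)F)Oc4ccccc4C=C3C(=O)O)on2)cc1`: in this assay compound 2 gives 51200 nM.
Compound 3 `CCOC(=O)C1=Cc2ccccc2OC1(OCc1cn(CC(=O)Nc2ccccc2F)nn1)C(F)(F)F`: in this assay compound 3 gives 50100 nM.

Of the three results, that for compound 1 is a limit rather than a number. Compound 2 stands alongside compound 3, the two numbers lying within the usual scatter of each other. For the measured compounds named here, the only measured step, an at least 2.9-fold lower number from compound 1 to compound 2 (0.46 log units; beyond the scatter), sits at another place in the molecule and carries no information about the aryl group.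

Compound 4 `O=C(O)C1=Cc2ccccc2OC1(OCc1cc(-c2cccc(C(F)(F)F)c2)no1)C(F)(F)F` differs from compound 2 by 3-(trifluoromethyl)phenyl in place of 4-methylphenyl on an aromatic carbon. Going by the values given here, with no measured step touching that position, no change beyond the scatter is expected in this assay. Compound 4 is therefore estimated at 50000 nM, with a range from 15000 nM to 150000 nM. The expected step is a 1.0-fold lower number from compound 2 to compound 4 (0.01 log units; within the scatter).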

Compound 4, half-maximal inhibitory concentration: > 150000 nM
Compound 4: a limit, no number; the forecaster's own chance of this, stated with the estimate: 20%; middle value at least 3.0-fold (0.47 log units) from the limit.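

The position on the five-membered aromatic ring next to the ring nitrogen is not silent. In this assay, for the compounds shown here, 3-(trifluoromethyl)phenyl in place of 4-methylphenyl gives an at least 2.9-fold higher number from compound 2 to compound 4 (0.46 log units; beyond the scatter), the first measured step at this position. Compound 4 gives a limit and not a number, so the step's full size stays unknown: the limit of > 150000 nM in this assay, at which 2 of the 4 values shown sit.

The compounds shown hold only these two aryl groups at this position, so one step cannot separate the gain of trifluoromethyl from the loss of methyl. Going by these compounds, how an amine or a methoxy group on that phenyl ring would read remains open.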